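The source may report more compounds than this note shows. Statements on the series, on what has been measured and on what is new or still open speak of the compounds shown alone.

Measured in an assay on CHO cells for binding affinity to transient receptor potential cation channel subfamily V member 1 (Rattus norvegicus); a lower number here means a stronger inhibitor, a higher number a weaker inhibitor:

compound 1 `CC(C)(C)C(=O)OCC(Cc1ccc(C(C)(C)C)cc1)CN(O)/C(S)=N/Cc1ccc(NS(C)(=O)=O)c(F)c1` gives 405 nM
compound 2 `COc1cc(C/N=C(\S)N(O)CC(COC(=O)C(C)(C)C)Cc2ccc(C)c(C)c2)ccc1NS(C)(=O)=O` gives 396 nM
compound 3 `Cc1ccc(CC(CNC(=S)N(O)Cc2ccc(NS(C)(=O)=O)cc2)COC(=O)C(C)(C)C)cc1C` gives 481 nM

On these three numbers compound 3 has the highest value, but its gap to compound 1 and its gap to compound 2 both fall within the usual scatter, so the three compounds cannot be separated in this assay.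

Compound 4 `Cc1ccc(CC(CNC(=S)N(O)Cc2ccc(NS(C)(=O)=O)c(F)c2)COC(=O)C(C)(C)C)cc1C` differs from compound 3 by fluoro in place of hydrogen on an aromatic carbon. Among the measured compounds shown here, no measured pair isolates this change: compound 1 carries the same fluoro, yet differs from compound 3 in several other parts, so its value speaks only for itself and gives no read on the fluoro alone. With the three measured compounds sitting so close together, and the change confined to one fluorine on the aromatic ring, the step from compound 3 to compound 4 is expected to be small, in no clear direction, and not beyond the scatter: the expected step is a 1.1-fold lower number from compound 3 to compound 4 (0.06 log units; within the scatter). Compound 4 is therefore estimated at 420 nM in this assay, with a range of 200 nM to 900 nM.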

Compound 4, inhibition constant: 546 nM
The estimate for compound 4 lay 1.3-fold (0.11 log units) below the measured number, within the range that was stated.
By their numbers in this assay, from the lowest: compounds 2, 1, 3 and 4 (each within the scatter of the next).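

In this assay the pair differing only in this place gives a 1.1-fold higher number from compound 3 to compound 4 (0.06 log units; within the scatter) for fluoro in place of hydrogen, ortho to the methanesulfonamido group. This is the only pair shown that isolates the change from 4-(methanesulfonamido)phenyl to 3-fluoro-4-(methanesulfonamido)phenyl, and it shows that this single fluoro gives no readable shift at this position with the rest of compound 3 held constant. No evidence at hand bears on this step.

The compounds shown leave open whether a larger group at this aromatic carbon, such as chloro or trifluoromethyl, would give a step beyond the scatter. Also open, on these data alone, is whether the fluoro step would read the same alongside the tert-butyl group of compound 1, which has no partner here differing in one place.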